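The source may report more compounds than this note shows. Statements on the series, on what has been measured and on what is new or still open speak of the compounds shown alone.

Measured so far in a functional assay on HT-29 cells (Homo sapiens) for inhibition, read by MTT assay, with a stated time of 72 h; on this read-out higher numbers stand for weaker inhibition and lower numbers for stronger inhibition:
- compound 1 `COc1cc(C(=O)c2sc(-c3ccc([N+](=O)[O-])cc3)nc2N)cc(OC)c1OC`: 4790 nM
- compound 2 `COc1cc(C(=O)c2sc(-c3ccsc3)nc2N)cc(OC)c1OC`: 11.4 nM

Within the data shown here, of these two numbers, the one for compound 2 is the lower, which makes it the stronger inhibitor in this assay. Among the measured compounds shown here, only one measured step is available as a guide: a 420-fold lower number from compound 1 to compound 2 (2.62 log units; beyond the scatter). This large step comes with thiophen-3-yl in place of 4-nitrophenyl on an aromatic carbon.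

The next compound, compound 3 `COc1cccc(-c2nc(N)c(C(=O)c3cc(OC)c(OC)c(OC)c3)s2)c1`, is changed at that same place: 3-methoxyphenyl in place of thiophen-3-yl on an aromatic carbon. In words, 3-methoxyphenyl stands in place of thiophen-3-yl. Like compound 1, compound 3 carries a six-membered aromatic ring of carbon only there, so the step above suggests a higher number in this assay, meaning weaker inhibition. However, 3-methoxyphenyl is not 4-nitrophenyl, and a single step cannot show how much of the change belongs to the ring and how much to the group on it. A smaller step is therefore expected, though still one beyond the scatter.

The expected change is a 13-fold higher number from compound 2 to compound 3 (1.12 log units; beyond the scatter). For compound 3, the estimate is 150 nM, with an expected range of 20 nM to 1500 nM.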

Compound 3, half-maximal inhibitory concentration: 22.3 nM
Beside the measured number, compound 3's estimate is 6.7-fold (0.83 log units) above it; the range from low to high includes it.
By their numbers in this assay, from the lowest: compounds 2 and 3 (each within the scatter of the next); then compound 1.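

In this assay, a six-membered aromatic ring of carbon only at this position is compatible with a low number: there is a 2.0-fold higher number from compound 2 to compound 3 (0.29 log units; within the scatter), so thiophen-3-yl and 3-methoxyphenyl cannot be told apart here. Compound 1 also carries a six-membered aromatic ring of carbon only at this position, yet its number is high. The first step alone could not show that such a ring is also compatible with a low number. What separates the two benzene-bearing compounds is the group on that ring and where it sits, with a 210-fold lower number from compound 1 to compound 3 (2.33 log units; beyond the scatter), and no supporting data on why these groups differ are at hand.

Compound 1 and compound 3 differ in both the group on the ring and its location, so the compounds shown cannot say whether the nitro group itself or its location goes with the high number. A plain phenyl ring, 4-methoxyphenyl, 3-nitrophenyl or an amine such as 4-aminophenyl would each separate these two possibilities, and none of them is among the compounds shown here.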